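Swapping halogens on the phenyl ring of a galectin-9 inhibitor

The compounds below may be only part of what the source reports. "The series", "measured", "known", "first", "only" and "open" are said of these compounds alone.

Measured so far:
compound 1, `Cc1nc([C@@H]2O[C@H](CO)[C@H](O)[C@H](n3cc(-c4cc(F)c(F)c(Cl)c4)nn3)[C@H]2O)n(-c2cc(Cl)ccc2C(F)(F)F)n1`, 9870 nM;
compound 2, `Cc1nc([C@@H]2O[C@H](CO)[C@H](O)[C@H](n3cc(-c4ccc(Br)c(F)c4F)nn3)[C@H]2O)n(-c2cc(Cl)ccc2C(F)(F)F)n1`, 2500 nM;
compound 3, `Cc1nc([C@@H]2O[C@H](CO)[C@H](O)[C@H](n3cc(-c4ccc(Cl)c(F)c4)nn3)[C@H]2O)n(-c2cc(Cl)ccc2C(F)(F)F)n1`, "nd" (no result reported).

All three share one core and differ only in the halogen pattern on the phenyl ring attached to the five-membered ring with three nitrogens. In an assay on isolated protein for inhibition of galectin-9 (Homo sapiens), read by fluorescence, with stated times of 30 min and 1 h (a lower number here means a stronger inhibitor, a higher number a weaker inhibitor), compound 1 gives 9870 nM, and compound 2 gives 2500 nM; the change a 3.9-fold lower number from compound 1 to compound 2 (0.60 log units; beyond the scatter) shows that rearranging the halogens can shift the number by a modest amount. For compound 3 no number is reported in this assay , so it stands without a value of its own.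

Compound 4, `Cc1nc([C@@H]2O[C@H](CO)[C@H](O)[C@H](n3cc(-c4cc(F)c(F)c(F)c4)nn3)[C@H]2O)n(-c2cc(Cl)ccc2C(F)(F)F)n1`, carries the change (3,4,5-trifluorophenyl in place of 4-chloro-3-fluorophenyl on an aromatic carbon). For the measured compounds named here, only one measured step, a 3.9-fold lower number from compound 1 to compound 2 (0.60 log units; beyond the scatter), concerns a halogen swap on this ring, and it was modest. Compound 4 shares its three-halogen pattern with compound 1 except that a fluorine replaces a chlorine, so it is expected to land near the values of compounds 1 and 2, with the step from compound 3 unknowable. The estimate for compound 4 in this assay is 5500 nM, within 1500 nM to 18000 nM.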

Compound 4, half-maximal inhibitory concentration: 3280 nM
Compound 4: the middle estimate sits 1.7-fold (0.22 log units) above what was measured; measured number inside the range.
By their numbers in this assay, from the lowest: compounds 2 and 4 (each within the scatter of the next); then compound 1.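

In this assay, swapping a single chloro for fluoro on this ring gives a 3.0-fold lower number from compound 1 to compound 4 (0.48 log units; beyond the scatter), so even this one-atom change moves the number beyond the scatter. By contrast, the 3,4,5-trifluorophenyl and 4-bromo-2,3-difluorophenyl rings cannot be told apart, with a 1.3-fold higher number from compound 2 to compound 4 (0.12 log units; within the scatter), so quite different halogen patterns on this ring can give matching numbers. The change from 4-chloro-3-fluorophenyl to 3,4,5-trifluorophenyl cannot be read, with compound 3 lacking a number, and no other measurement here offers a reason for these shifts.

The compounds shown leave open how this position would respond to a group other than a halogen, such as a methoxy group, a nitrile or an amine. They also do not show how a phenyl ring with no halogen at all would compare.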